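The compounds below may be only part of what the source reports. "The series", "measured", "known", "first", "only" and "open" are said of these compounds alone.

Measured so far in a functional assay on DU-145 cells (Homo sapiens) for inhibition, read by trypan blue exclusion, with a stated time of 96 h; on this read-out lower numbers stand for stronger inhibition of growth and higher numbers for weaker inhibition of growth: compound 1 `Cc1ccc(S/C(=C/c2c[nH]c3ccccc23)C(=O)c2ccc(Br)cc2)cc1` gives 10000 nM; compound 2 `Cc1ccc(S/C(=C/c2ccc(Cl)c(Cl)c2)C(=O)c2ccc(Br)cc2)cc1` gives 50000 nM; compound 3 `CSc1ccc(/C=C(/SCc2ccc(C)cc2)C(=O)c2ccc(Br)cc2)cc1` gives > 100000 nM.

For compound 3 the value is a limit of this assay, not a number (the limit of > 100000 nM in this assay, at which 1 of the 3 values shown sits). Among the compounds with values here, the one step measured, a 5.0-fold higher number from compound 1 to compound 2 (0.70 log units; beyond the scatter), concerns a change on the double-bonded chain carbon and not the sulfur substituent, so no measured step bears on the change to compound 4 `CSc1ccc(/C=C(/Sc2ccc(C)cc2)C(=O)c2ccc(Br)cc2)cc1`: 4-methylphenyl in place of 4-methylbenzyl on a sulfur. Compounds 1 and 2 both carry 4-methylphenyl on a sulfur, and compound 2 gives 50000 nM in this assay. Compound 4 is therefore expected to give a number rather than a limit, near 50000 nM, between 15000 nM and 150000 nM. The expected step is an at least 2.0-fold lower number from compound 3 to compound 4 (0.30 log units; that floor lies within the scatter), in the direction of stronger inhibition.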

Compound 4, concentration for 50% growth inhibition: 50000 nM
Estimate against measurement, compound 4: no gap at the digits printed; low and high end bracket the measured number.
By their numbers in this assay, from the lowest: compound 1; then compounds 2 and 4 (each within the scatter of the next). At a limit, above all of these: compound 3.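

In this assay compound 3 stands at a limit, not a number: (the limit of > 100000 nM in this assay, at which 1 of the 4 values shown sits).
On the sulfur, 4-methylphenyl in place of 4-methylbenzyl gives a measurable number (an at least 2.0-fold lower number from compound 3 to compound 4 (0.30 log units; that floor lies within the scatter)). With 4-methylphenyl on the sulfur in all three, 4-(methylsulfanyl)phenyl on the double-bonded chain carbon reads the same as 3,4-dichlorophenyl (no change at the digits printed from compound 2 to compound 4 (within the scatter)), and 1H-indol-3-yl remains the stronger group there (a 5.0-fold higher number from compound 1 to compound 4 (0.70 log units; beyond the scatter)).

Still open, as far as these compounds go, is how a 2-phenylethyl group on the sulfur would read. Also open, from the compounds shown here alone, is whether a carboxylic acid or an amine on the group at the double-bonded chain carbon would match 1H-indol-3-yl.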